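Oxan-4-yl for Cyclobutyl on the Amide of Compound 2

A few compounds are considered here, and "the series" means these few. Any claim that something is new, unique, unknown or untested is made for them only; others in the source may bear on it.

Compound 1 `O=C1NCCc2nc(C#Cc3ccccc3F)sc21`: in an assay on HEK293 cells for negative allosteric modulation of metabotropic glutamate receptor 5 (Homo sapiens), read by FLIPR, with a stated time of 1 h (a lower number here means a stronger inhibitor, a higher number a weaker inhibitor), compound 1 reaches only the limit > 10000 nM, which is a limit of the assay and not a number.
Compound 2 `O=C(C1CCC1)N1CCc2nc(C#Cc3ccccc3)sc2C1`: in this assay compound 2 gives 370 nM.

For the measured compounds named here, compound 2 thus holds the only numerical value in this assay; the other entry sits at the limit (the limit of > 10000 nM in this assay, at which 1 of the 2 values shown sits), so compound 2 cannot be ranked against any measured neighbour. Going by the values given here, compound 1 and compound 2 differ in more than one place, and no single-point step between measured compounds is available.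

Compound 3 `O=C(C1CCOCC1)N1CCc2nc(C#Cc3ccccc3)sc2C1` has not yet been measured. It differs from compound 2 in one place: oxan-4-yl in place of cyclobutyl on a carbonyl carbon. Nothing measured here shows what this change does, so the expectation rests on compound 2 alone. A step of modest size is expected in this assay, most likely toward a somewhat weaker value, though it may well fall within the usual scatter. Compound 3 is therefore estimated at about 550 nM, expected to lie between 200 nM and 1600 nM. The expected shift is a 1.5-fold higher number from compound 2 to compound 3 (0.17 log units; within the scatter).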

Compound 3, half-maximal inhibitory concentration: > 10000 nM
Compound 3: only a limit was reported; the forecaster's own chance of this, stated with the estimate: 5%; middle value at least 18-fold (1.25 log units) from the limit.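

For the compounds shown here, at the carbonyl carbon of the amide, the group is not freely interchangeable: in this assay the replacement of cyclobutyl by oxan-4-yl gives an at least 27-fold higher number from compound 2 to compound 3 (1.43 log units; beyond the scatter) as the first single-point step, and it is a large one. Compound 3 reaches > 10000 nM in this assay, which is a limit of the assay and not a number, so the step has a lower bound but no exact size. Compound 2 therefore remains the only compound here with a numerical value, and its activity is shown to depend on the group at this position, while the remaining entries sit at the ceiling: the limit of > 10000 nM in this assay, at which 2 of the 3 values shown sit.

The change enlarges the ring from four-membered to six-membered and brings in a ring oxygen with one hydrogen-bond acceptor at the same time, and the compounds shown do not separate these two differences. A cyclohexyl group on the same carbonyl carbon would address the ring size without the oxygen, whereas an oxetan-3-yl group would test the ring oxygen in a smaller ring.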